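Lengthening the hydroxycarbamoyl chain from compound 3 to compound 4

The compounds below may be only part of what the source reports. "The series", "measured", "known", "first", "only" and "open" are said of these compounds alone.

Among the compounds with values here, in a functional assay on Huh-7 cells (Homo sapiens) for inhibition, read by MTT assay, with a stated time of 72 h (on this read-out lower numbers stand for stronger inhibition and higher numbers for weaker inhibition), compound 3 `Nc1nc2cc(-c3nn(CCCCC(=O)NO)c4ncnc(N)c34)ccc2o1` gives 9220 nM as the lowest of the three numbers so far. Compound 1 `CNC(=O)CCCCCCCn1nc(-c2cnc3[nH]ccc3c2)c2c(N)ncnc21` stands at 23500 nM on this read-out, and compound 2 `Nc1nc2cc(-c3nn(CCCCCCCCCC(=O)NO)c4ncnc(N)c34)ccc2o1` stands at 41200 nM on the same scale. Compound 1 differs from compound 3 in more than one place and offers no guide here.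

Compound 4 `Nc1nc2cc(-c3nn(CCCCCC(=O)NO)c4ncnc(N)c34)ccc2o1` follows from compound 3 through (hydroxycarbamoyl)methyl in place of hydroxycarbamoyl on a saturated chain carbon, four bonds along the chain from an aromatic nitrogen with (hydroxycarbamoyl)methyl in place of hydroxycarbamoyl on a saturated chain carbon, four bonds along the chain from an aromatic nitrogen. Within the data shown here, the only measured step at this place is a 4.5-fold lower number from compound 2 to compound 3 (0.65 log units; beyond the scatter) for a much larger shortening of the chain, and a single step sets no trend. The chain of compound 4 is longer than that of compound 3 and shorter than that of compound 2, so a slight rise is the likely direction, with no step beyond the scatter expected in this assay for so small a change. The expected step is a 1.1-fold higher number from compound 3 to compound 4 (0.06 log units; within the scatter) and stays within the scatter. Compound 4 is estimated at 10500 nM with an expected range from 4500 nM to 24000 nM for now.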

Compound 4, half-maximal inhibitory concentration: 9910 nM
For compound 4 the middle estimate is 1.1-fold (0.03 log units) above the measured one; the measured number falls inside the stated range.
By their numbers in this assay, from the lowest: compounds 3 and 4 (each within the scatter of the next); then compounds 1 and 2 (each within the scatter of the next).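

In this assay, (hydroxycarbamoyl)methyl in place of hydroxycarbamoyl gives a 1.1-fold higher number from compound 3 to compound 4 (0.03 log units; within the scatter) and so leaves the number within the scatter at this position on the chain. Hydroxycarbamoyl in place of 4-(hydroxycarbamoyl)butyl gives a 4.2-fold lower number from compound 2 to compound 4 (0.62 log units; beyond the scatter) and thus shows that the two shorter chains sit together, while the longest chain shown stands apart from both, so the response to chain length is not an even slope across these three compounds. No measurement is at hand that explains these numbers.

The chain length at which the numbers begin to rise remains open, as the compounds shown leave a wide gap below the longest chain. Also open, going by these compounds, is whether a shorter chain, or a carboxylic acid in place of the hydroxycarbamoyl end, would hold the number on the shared core.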